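The source may report more compounds than this note shows. Statements on the series, on what has been measured and on what is new or still open speak of the compounds shown alone.

Measured so far: compound 1 `Cc1nn(C)c2c1C(c1ccccc1Cl)=NCC(=O)N2` gives 16 mg/kg in a functional assay on the whole organism with Rattus norvegicus as the target; a lower number here means that less compound is needed, a higher number that more compound is needed for the effect; compound 2 `CCc1nn(C)c2c1C(c1cccc(F)c1)=NCC(=O)N2` gives 32 mg/kg; compound 3 `CCc1nn(C)c2c1C(c1ccc(F)cc1)=NCC(=O)N2` stands apart. For compound 3 the result is only a limit, > 500 mg/kg, the point marked by the limit of > 500 mg/kg in this assay, at which 1 of the 3 values shown sits.

Among the compounds with values here, the single measured step, an at least 15-fold higher number from compound 2 to compound 3 (1.19 log units; beyond the scatter), is large and beyond the scatter, and it is the only comparison that bears on the change at hand. Compound 4 `CCc1nn(C)c2c1C(c1ccccc1Cl)=NCC(=O)N2` differs from compound 3 by 2-chlorophenyl in place of 4-fluorophenyl on a carbon with a double bond to nitrogen. Compound 4 thus carries the 2-chlorophenyl that compound 1 carries and otherwise matches compound 2, and the values of compound 1 and compound 2 lie within the scatter of each other. A large fall is therefore expected, an at least 25-fold lower number from compound 3 to compound 4 (1.39 log units; beyond the scatter). Compound 4 is expected to give about 20 mg/kg, within 8 mg/kg to 60 mg/kg.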

Compound 4, minimum effective dose: 32 mg/kg
For compound 4 the middle estimate is 1.6-fold (0.20 log units) below the measured one, and the stated range covers the measured number.
By their numbers in this assay, from the lowest: compounds 1, 2 and 4 (each within the scatter of the next). At a limit, above all of these: compound 3.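

On the carbon with a double bond to nitrogen, 2-chlorophenyl in place of 4-fluorophenyl gives an at least 15-fold lower number from compound 3 to compound 4 (1.19 log units; beyond the scatter), so the shared core with its ethyl group can reach the low numbers, and the high one goes with 4-fluorophenyl alone. Compound 3 remains a limit, not a number: the limit of > 500 mg/kg in this assay, at which 1 of the 4 values shown sits 2-Chlorophenyl and 3-fluorophenyl are not told apart here, with no change at the digits printed from compound 2 to compound 4 (within the scatter), and methyl in place of hydrogen on the chain also leaves the result within the scatter, with a 2.0-fold higher number from compound 1 to compound 4 (0.30 log units; within the scatter). From the compounds shown here alone, whether plain phenyl or 4-chlorophenyl at this place would behave like compound 3 stays open, as does the effect of a longer chain than ethyl.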